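From fluoro to methoxy on a benzyl group

This account rests on a few compounds, and the source may have more. Where it says the series, first, only, none or still open, it means among the compounds named here.

Compound 1 `COc1ccc2cc([C@H](C)c3nnc(SCc4ccc(Cl)cc4)n3-c3ccc(F)cc3)ccc2c1`: <= 400000 nM (a limit)
Compound 2 `COc1ccc(CSc2nnc([C@@H](C)c3ccc4cc(OC)ccc4c3)n2-c2ccc(Cl)cc2)cc1`: <= 400000 nM (a limit)
Compound 3 `COc1ccc2cc([C@H](C)c3nnc(SCc4ccc(F)cc4)n3-c3ccc(F)cc3)ccc2c1`: <= 400000 nM (a limit)

All three compounds were tested in a functional assay on PC-3 cells (Homo sapiens) for cytotoxicity, read by MTT assay; on this read-out higher numbers stand for weaker inhibition and lower numbers for stronger inhibition. Compound 3 stands at <= 400000 nM, which is a limit and not a number. The other two compounds give limits as well, so the numbers offer one kind of evidence only: the limit of <= 400000 nM in this assay, at which 3 of the 3 values shown sit.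

The next compound, compound 4 `COc1ccc(CSc2nnc([C@@H](C)c3ccc4cc(OC)ccc4c3)n2-c2ccc(F)cc2)cc1`, differs from compound 3 in one group: methoxy in place of fluoro on an aromatic carbon. Methoxy takes the place of fluoro on an aromatic carbon, so 4-fluorobenzyl becomes 4-methoxybenzyl.

Among the measured compounds shown here, the one measured step at that place is a step that the two limits leave unreadable from compound 1 to compound 3, with fluoro in place of chloro on an aromatic carbon. It gives no size to build on. Compound 2 also carries the 4-methoxybenzyl group, and its <= 400000 nM is again a limit.

No step beyond the usual scatter is therefore expected in this assay, in either direction. The expected step is a step that the limit leaves unreadable from compound 3 to compound 4. For compound 4 the estimated value is 300000 nM, with an expected range from 100000 nM to 400000 nM.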

Compound 4, half-maximal inhibitory concentration: 400000 nM
For compound 4 the middle estimate is 1.3-fold (0.12 log units) below the measured one, within the range that was stated.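

In this assay, among the compounds shown here, compound 4 gives 400000 nM, the first plain number in this set, and 4-methoxybenzyl in place of 4-fluorobenzyl gives a number no lower from compound 3 to compound 4 (the limit leaves the size open). Compound 3 still has only a limit, <= 400000 nM. Fluoro in place of chloro gives a number no lower from compound 2 to compound 4 (the limit leaves the size open), and methoxy in place of chloro gives a number no lower from compound 1 to compound 4 (the limit leaves the size open). Going by these compounds, the size of all three steps cannot be read, so the size of the change from fluoro to methoxy stays unknown, and the evidence remains mostly of one kind: the limit of <= 400000 nM in this assay, at which 3 of the 4 values shown sit.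

The compounds shown leave open whether any group on this aromatic carbon can shift the value by a readable amount. An amine, a carboxylic acid or a longer chain in place of methoxy could test that.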